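Homologating the acid chain: from compound 3 to compound 4

The compounds below may be only part of what the source reports. "The series", "measured", "known", "first", "only" and "open" are said of these compounds alone.

The series rests on the core of compound 1 `Cc1ccccc1-c1noc(-c2ccc(C3CCCCC3)cc2)n1`, which carries no acid and in a functional assay on CHO cells for agonist activity at sphingosine 1-phosphate receptor 5 (Homo sapiens), read by GTPgammaS binding (a lower number here means that less compound is needed, a higher number that more compound is needed for the effect), gives 266 nM. Compound 2 `Cc1cc(CC(=O)O)ccc1-c1noc(-c2ccc(C3CCCCC3)cc2)n1` adds a carboxymethyl on an aromatic carbon and in this assay gives 4000 nM; compound 3 `Cc1cc(CCC(=O)O)ccc1-c1noc(-c2ccc(C3CCCCC3)cc2)n1` adds a 2-carboxyethyl at that aromatic carbon and gives 591 nM. Of the three numbers compound 3 stands second highest: the step of a 2.2-fold higher number from compound 1 to compound 3 (0.35 log units; beyond the scatter) is modest, whereas the acid is far less well tolerated in compound 2, where a 15-fold higher number from compound 1 to compound 2 (1.18 log units; beyond the scatter).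

Compound 4 `Cc1cc(CCCC(=O)O)ccc1-c1noc(-c2ccc(C3CCCCC3)cc2)n1` extends the chain once more: carboxymethyl in place of carboxy on a saturated chain carbon, two bonds along the chain from an aromatic carbon. Among the compounds with values here, the one measured step of the same kind, a 6.8-fold lower number from compound 2 to compound 3 (0.83 log units; beyond the scatter), ran strongly in the favourable direction. No second homologation exists in the set, so whether that trend continues, flattens, or reverses cannot be read from the data; compound 1 shows that an acid-free analogue sits only a little below compound 3.

A small change is therefore expected, most likely a slightly lower number but within the scatter, with wide uncertainty on both sides. The expected step is a 1.5-fold lower number from compound 3 to compound 4 (0.17 log units; within the scatter). For compound 4 the estimate in this assay is 400 nM, between 120 nM and 1500 nM.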

Compound 4, half-maximal effective concentration: 840 nM
Compound 4: the middle estimate sits 2.1-fold (0.32 log units) below what was measured; measured number inside the range.
By their numbers in this assay, from the lowest: compound 1; then compounds 3 and 4 (each within the scatter of the next); then compound 2.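

Extending 2-carboxyethyl to 3-carboxypropyl at this position shows that in this assay the gain from the earlier homologation does not continue: the step is a 1.4-fold higher number from compound 3 to compound 4 (0.15 log units; within the scatter), so compound 3 and compound 4 cannot be told apart. The longer chain still stands well clear of the carboxymethyl analogue, with a 4.8-fold lower number from compound 2 to compound 4 (0.68 log units; beyond the scatter), so among these three acids the sharp dependence on chain length appears only at the shortest chain, and the two longer chains form a plateau. That plateau does not reach the acid-free core, with a 3.2-fold higher number from compound 1 to compound 4 (0.50 log units; beyond the scatter), so none of compounds 2, 3 and 4 matches compound 1, and the third chain length offers no advantage over the second.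

The compounds shown leave open whether a longer chain than 3-carboxypropyl would stay on this plateau, and whether an amine in place of the carboxylic acid at the chain end would close the remaining gap to compound 1. No measurement at hand bears on why the chain length stops mattering here.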